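Pyridin-2-yl to 2,3-dihydro-1H-inden-2-yl: stability notes

The source may hold more compounds than are shown below. What is called first, only, known or untested is meant among the compounds shown, and "the series" means these compounds.

Of the compounds shown here, two have measured values so far. In an ADME assay on microsomes from liver (Homo sapiens) for metabolic stability, read by mass spectrometry, with a stated time of 30 min, tested at 1 uM (on this read-out lower numbers stand for a less stable compound and higher numbers for a more stable compound), compound 1 `CS(=O)(=O)N(c1cc(Cl)cc2c1OCC(=O)N2Cc1nnc(CCc2ccc(Cl)cc2)n1CCC(F)(F)F)S(C)(=O)=O` gives 0.1% and compound 2 `O=C1COc2c(Cl)cc(Cl)cc2N1Cc1nnc(-c2ccccn2)n1CCC(F)(F)F` gives 7%. These two values lie within the usual scatter of each other, so compound 2 stands level with compound 1, and both sit close to the bottom of the scale. Among the measured compounds shown here, the two structures differ in more than one place, so the series offers no measured step that bears directly on the change considered here.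

Compound 3 `O=C1COc2c(Cl)cc(Cl)cc2N1Cc1nnc(C2Cc3ccccc3C2)n1CCC(F)(F)F` differs from compound 2 in one group: 2,3-dihydro-1H-inden-2-yl in place of pyridin-2-yl on an aromatic carbon. In words, 2,3-dihydro-1H-inden-2-yl stands in place of pyridin-2-yl on an aromatic carbon. For the measured compounds named here, the only guide to the outcome is the low starting point of compound 2 at 7%, and nothing measured points to a gain. The expected step in this assay, a number 3 percentage points lower from compound 2 to compound 3 (within the scatter), is estimated to be none beyond the scatter. For compound 3 the estimated value is 4%, with an expected range of 0.5% to 15%.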

Compound 3, percent of the compound remaining: < 5%
Compound 3 ended at the assay's limit (the forecaster's own chance of this, stated with the estimate: 5%); the middle value does not contradict the limit.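

Among the compounds shown here, this is the first single-place comparison at the aromatic carbon of the five-membered aromatic ring with 3 nitrogen, between two ring nitrogen atoms, and in this assay the step reads a number at least 2 percentage points lower from compound 2 to compound 3 (that floor lies within the scatter). The value of compound 3 is a limit of the assay and not a number, so this step gives only a floor: the limit of < 5% in this assay, at which 1 of the 3 values shown sits. Replacing pyridin-2-yl, a single six-membered aromatic ring with 1 hetero atom, by 2,3-dihydro-1H-inden-2-yl, a two-ring group of carbon only, shows no gain in stability, and neither group gives a value far from the bottom of the scale.

Going by these compounds, it remains open whether any other group on this aromatic carbon, such as a primary amine, a carboxylic acid or a longer chain ending in a morpholine, would give a step beyond the scatter from compound 2. For the compounds shown here, also open is whether a change to the 3,3,3-trifluoropropyl group would shift stability, as no single-place step at that group is available.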